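The source may report more compounds than this note shows. Statements on the series, on what has been measured and on what is new or still open speak of the compounds shown alone.

Measured so far in an ADME assay on HepG2 cells (Homo sapiens) for cytotoxicity, read by fluorescence and resazurin assay, with a stated time of 24 h; on this read-out higher numbers stand for lower toxicity in this test and lower numbers for higher toxicity in this test:
Compound 1 `O=S1(=O)C=C(Sc2nnc(-c3ccc(Cl)cc3)o2)c2ccccc21` gives 22000 nM.
Compound 2 `COc1ccccc1-c1nnc(SC2=CS(=O)(=O)c3ccccc32)o1` gives 16000 nM.
Compound 3 `O=S1(=O)C=C(Sc2nnc(-c3cccc(Cl)c3)o2)c2ccccc21` gives 27000 nM.

Among these three, compound 3 sits at the upper end, yet every step between them is within the scatter: a 1.2-fold higher number from compound 1 to compound 3 (0.09 log units; within the scatter), a 1.7-fold higher number from compound 2 to compound 3 (0.23 log units; within the scatter) and a 1.4-fold lower number from compound 1 to compound 2 (0.14 log units; within the scatter). All three share one core and differ only in the aromatic group on the five-membered aromatic ring with 2 nitrogen and 1 oxygen. Compound 4 `O=S1(=O)C=C(Sc2nnc(-c3ccccn3)o2)c2ccccc21` changes that same group once more: pyridin-2-yl in place of 3-chlorophenyl on an aromatic carbon. The three measured steps each swapped one such aromatic group for another at this place, and none moved the number beyond the scatter, so no step beyond the scatter is expected here either: a 1.1-fold lower number from compound 3 to compound 4 (0.05 log units; within the scatter). Compound 4 is therefore estimated at 24000 nM, with a range from 11000 nM to 55000 nM in this assay.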

Compound 4, half-maximal cytotoxic concentration: 24000 nM
Beside the measured number, compound 4's estimate shows no gap at the digits printed, within the range that was stated.
By their numbers in this assay, from the lowest: compounds 2, 1, 4 and 3 (each within the scatter of the next).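

Pyridin-2-yl, a six-membered aromatic ring with 1 hetero atom and 1 hydrogen-bond acceptor, stays within the scatter against all three earlier groups (a 1.1-fold lower number from compound 3 to compound 4 (0.05 log units; within the scatter); a 1.5-fold higher number from compound 2 to compound 4 (0.18 log units; within the scatter); a 1.1-fold higher number from compound 1 to compound 4 (0.04 log units; within the scatter)). This position has now taken a ring with a hetero atom as well as substituted phenyl rings, with no step beyond the scatter. No measured evidence bears on the cause of this result. Still open, from the compounds shown here alone, is whether an amine, a carboxylic acid or a longer alkyl chain at this place would move the number beyond the scatter.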